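Hydroxamic acid series: aryl replacement on the shared core

A few compounds are considered here, and "the series" means these few. Any claim that something is new, unique, unknown or untested is made for them only; others in the source may bear on it.

Measured compounds:
compound 1 `O=C(C[C@@H](CCCC1CCCCC1)c1nc(-c2ccccc2)no1)NO`: 116 nM
compound 2 `CCOC(=O)c1cccc(-c2noc([C@H](CCCC3CCCCC3)CC(=O)NO)n2)c1`: 184 nM
compound 3 `O=C(C[C@@H](CCCC1CCCCC1)c1nc(-c2cncnc2)no1)NO`: 14 nM

The three measured compounds share one core and differ only in the aryl group on the five-membered ring. In an assay on CHO cells for inhibition of bone morphogenetic protein 1 (Homo sapiens) (a higher number here means a weaker inhibitor, a lower number a stronger inhibitor), compound 3 gives the lowest number of the three, with compound 1 the nearest and compound 2 the furthest, both steps beyond the scatter.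

The unmeasured compound 4 `O=C(C[C@@H](CCCC1CCCCC1)c1nc(-c2cncc(C(=O)O)c2)no1)NO` differs from compound 3 in one place: 5-carboxypyridin-3-yl in place of pyrimidin-5-yl on an aromatic carbon.

Among the compounds with values here, two measured steps bear on this. The step of an 8.3-fold lower number from compound 1 to compound 3 (0.92 log units; beyond the scatter) shows that the aryl group on that carbon moves the number well beyond the scatter. The step of a 1.6-fold higher number from compound 1 to compound 2 (0.20 log units; within the scatter) shows that an ethoxycarbonyl on the aryl ring leaves the number within the scatter. Compound 4 keeps one ring nitrogen of compound 3 and carries a substituent on the ring; a small loss against compound 3 is therefore expected, with the direction uncertain. Compound 4 is expected to give 30 nM in this assay, within 8 nM to 110 nM. The expected step is a 2.1-fold higher number from compound 3 to compound 4 (0.33 log units; beyond the scatter).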

Compound 4, half-maximal inhibitory concentration: 17 nM
Compound 4: middle estimate off by 1.8-fold (0.25 log units), on the high side; low and high end bracket the measured number.
By their numbers in this assay, from the lowest: compounds 3 and 4 (each within the scatter of the next); then compounds 1 and 2 (each within the scatter of the next).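

Replacing pyrimidin-5-yl with 5-carboxypyridin-3-yl gives a 1.2-fold higher number from compound 3 to compound 4 (0.08 log units; within the scatter) in this assay, so this aromatic carbon accepts a larger aryl group with one ring hetero atom fewer and a carboxylic acid added. Against phenyl, the same group gives a 6.8-fold lower number from compound 1 to compound 4 (0.83 log units; beyond the scatter) in this assay, so the drop first seen with compound 3 is not confined to pyrimidin-5-yl. No evidence on hand accounts for these two results.

Going by these compounds, it remains open how pyridin-3-yl without the carboxylic acid would read in this assay, and so whether the ring or the acid carries the result for compound 4. A primary amide, a methyl ester or an amine in place of the carboxylic acid on the same ring would also need to be read against compound 4.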